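The compounds below may be only part of what the source reports. "The series", "measured", "known", "first", "only" and "open" are said of these compounds alone.

Working notes on a urea series in an assay on HEK293 cells for inhibition of transient receptor potential cation channel subfamily V member 1 (Homo sapiens), read by FLIPR, at pH 5.5; a higher number here means a weaker inhibitor, a lower number a stronger inhibitor. Compound 1 `CC(C)c1ccc(NC(=O)N2CCN(c3ccc(-c4ccccc4)nn3)CC2)cc1` and compound 3 `Cc1cnnc(N2CCN(C(=O)Nc3ccc(C(C)C)cc3)CC2)c1` differ in more than one place; the difference between the two cores is not broken down here. Compound 1 gives > 10000 nM, which is a limit of the assay. Compound 2 `O=C(Nc1ccc(OC(F)(F)F)cc1)N1CCN(c2ccc(-c3ccccc3)nn2)CC1` gives > 10000 nM, likewise a limit. Among the compounds with values here, compound 3 gives 20300 nM, the only number among the three. The change trifluoromethoxy in place of isopropyl on an aromatic carbon makes a step that the two limits leave unreadable from compound 1 to compound 2; its size cannot be read because of the limit of > 10000 nM in this assay, at which 2 of the 3 values shown sit. Compound 4 `Cc1cnnc(N2CCN(C(=O)Nc3ccc(OC(F)(F)F)cc3)CC2)c1` carries the same change, (trifluoromethoxy in place of isopropyl on an aromatic carbon), on the core of compound 3, at a place described in the same words. A small step is expected, a 1.0-fold lower number from compound 3 to compound 4 (0.01 log units; within the scatter), resting only on compound 3 at 20300 nM. Compound 4 is therefore expected near 20000 nM, between 8000 nM and 60000 nM, with a fair chance that only a limit is reported.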

Compound 4, half-maximal inhibitory concentration: > 10000 nM
Compound 4: a limit, no number; the forecaster's own chance of this, stated with the estimate: 60%; the middle value lies beyond the limit too.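

No new step can be read from compound 3 to compound 4, because compound 4 gives only a limit: the limit of > 10000 nM in this assay, at which 3 of the 4 values shown sit. In this assay the compounds shown leave open whether trifluoromethoxy in place of isopropyl on an aromatic carbon shifts the number on either core.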